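A few compounds are considered here, and "the series" means these few. Any claim that something is new, unique, unknown or untested is made for them only; others in the source may bear on it.

Measured in a toxicity assay on NIH3T3 cells (Mus musculus) for cytotoxicity, read by resazurin assay; a lower number here means that less compound is needed, a higher number that more compound is needed for the effect:
compound 1 `COC(=O)c1ccc(NCc2cncn2Cc2ccccc2-c2ccccc2)cc1-c1ccccc1` gives "not determined" (no result reported)
compound 2 `COC(=O)c1ccc(NCc2cncn2Cc2cccc(C#N)c2)cc1-c1ccccc1` gives > 10000 nM

Compound 2 stands at the limit of > 10000 nM in this assay, at which 1 of the 2 values shown sits, which is a limit of the assay and not a number. Among the compounds with values here, compound 1 has no result, so no measured step is available. Compound 3 `COC(=O)c1ccc(NCc2cncn2Cc2ccc(C)cc2)cc1-c1ccccc1` is next, with 4-methylphenyl in place of 3-cyanophenyl on a saturated chain carbon bound to an aromatic nitrogen. In this assay no step beyond the scatter is expected, in either direction. The expected step that the limit leaves unreadable from compound 2 to compound 3 is therefore small. For compound 3 the estimate is 15000 nM, with an expected range from 5000 nM to 50000 nM.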

Compound 3, half-maximal effective concentration: 50000 nM
Compound 3: middle estimate off by 3.3-fold (0.52 log units), on the low side; measured number inside the range.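

Compound 2 stands at a limit and not a number, so no step to compound 3 can be read in this assay: the limit of > 10000 nM in this assay, at which 1 of the 3 values shown sits.

On these data alone, the size of any difference between 3-cyanobenzyl and 4-methylbenzyl in this assay stays open.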